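The compounds below may be only part of what the source reports. "The series", "measured", "known", "first", "only" and "open" are said of these compounds alone.

Compound 1 `CCC1C(=O)N(C)c2cnc(-n3ccc4cc(C(N)=O)ccc43)nc2N1c1ccn(C)n1` — 39500 nM
Compound 2 `CCC1C(=O)N(C)c2cnc(-n3ccc4cc(C(=O)NC)ccc43)nc2N1c1ccn(C)n1` — 43100 nM
Compound 3 `CCC1C(=O)N(C)c2cnc(-n3ccc4cc(C(=O)NCC(C)C)ccc43)nc2N1c1ccn(C)n1` — 19200 nM

All three were tested in a functional assay on A549 cells (Homo sapiens) for antiproliferative activity, read by CCK-8 assay, with a stated time of 72 h; a lower number here means a stronger inhibitor of growth, a higher number a weaker inhibitor of growth. Compound 3 gives the lowest of the three numbers: the step of a 2.1-fold lower number from compound 1 to compound 3 (0.31 log units; beyond the scatter) and the step of a 2.2-fold lower number from compound 2 to compound 3 (0.35 log units; beyond the scatter) both lie beyond the scatter, whereas the step of a 1.1-fold higher number from compound 1 to compound 2 (0.04 log units; within the scatter) does not. Replacing hydrogen on the amide-type nitrogen with isobutyl thus brought a modest gain, while methyl alone made no clear difference.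

Compound 4 `CCC1C(=O)N(C)c2cnc(-n3ccc4cc(C(=O)NC(C)C)ccc43)nc2N1c1ccn(C)n1` has not yet been measured. It differs from compound 3 in one place: isopropyl in place of isobutyl on an amide-type nitrogen Put another way, an isobutylcarbamoyl group becomes an isopropylcarbamoyl group.

Within the data shown here, no measured step swaps isobutyl for isopropyl directly. Among the measured compounds shown here, the steps that bear on it are the ones that build the group up from hydrogen: to methyl there was nothing beyond the scatter, and to isobutyl a modest gain. Isopropyl is the smaller of the two branched groups, so the number for compound 4 is expected to fall between those of compound 2 and compound 3, most likely a little above compound 3 but not clearly beyond the scatter. The step of a 1.4-fold higher number from compound 3 to compound 4 (0.15 log units; within the scatter) is therefore expected to be small. For compound 4 the estimate in this assay is 27000 nM, with a range from 12000 nM to 60000 nM.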

Compound 4, concentration for 50% growth inhibition: 22000 nM
Compound 4: the middle estimate sits 1.2-fold (0.09 log units) above what was measured, within the range that was stated.
By their numbers in this assay, from the lowest: compounds 3, 4, 1 and 2 (each within the scatter of the next, the first and the last beyond it).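

In this assay the change from isobutyl to isopropyl on the amide-type nitrogen gives a 1.1-fold higher number from compound 3 to compound 4 (0.06 log units; within the scatter) and so shows that removing this one carbon from the branched group leaves no difference that can be read. The other two steps add a complication: a 2.0-fold lower number from compound 2 to compound 4 (0.29 log units; within the scatter) and a 1.8-fold lower number from compound 1 to compound 4 (0.25 log units; within the scatter) both stay within the scatter, so compound 4 cannot be separated from any of the other three compounds, whereas compound 3 does stand apart from compound 1 and compound 2, and the modest gain seen with isobutyl is therefore neither clearly shared by isopropyl nor ruled out for it. Nothing given here explains these numbers or says why the two branched groups should behave alike.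

From the compounds shown here alone, it remains open whether a longer straight chain such as n-butyl, or a ring such as cyclohexyl or phenyl on the same nitrogen, would carry the number clearly beyond what isobutyl gives. Also unanswered is how a carboxylic acid or an amine in place of the whole carbamoyl group would compare on the shared core.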